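The source may report more compounds than this note shows. Statements on the series, on what has been measured and on what is new or still open speak of the compounds shown alone.

Compound 1 `C=Cc1ccnc(C#Cc2ccc3ncn(-c4ccnc(N)n4)c3c2)c1` gives 1580 nM in an assay on Sf9 cells for inhibition of mitogen-activated protein kinase kinase kinase 14 variant S549D (Homo sapiens), with a stated time of 30 min, in the presence of a further agent that is not named here; on this read-out higher numbers stand for weaker inhibition and lower numbers for stronger inhibition; compound 2 `C#Cc1nccc(C#Cc2ccc3ncn(-c4ccnc(N)n4)c3c2)n1` gives 39800 nM.

Compound 2 stands at the highest of the two numbers, its nearest neighbour being compound 1 at a 25-fold higher number from compound 1 to compound 2 (1.40 log units; beyond the scatter). As far as these compounds go, compound 3 `C#Cc1cncc(C#Cc2ccc3ncn(-c4ccnc(N)n4)c3c2)n1` is untested; it differs from compound 2 by a group of 8 heavy atoms (6 carbon, 2 nitrogen; one six-membered aromatic ring with 2 hetero atoms) in place of a group of 8 heavy atoms (6 carbon, 2 nitrogen; one six-membered aromatic ring with 2 hetero atoms), on a triple-bonded carbon. Going by the values given here, the one measured step concerns a different exchange on that triple-bonded carbon, so no step bears directly on this rearrangement. Compound 3 is therefore expected to stay near compound 2, with a step of a 1.3-fold lower number from compound 2 to compound 3 (0.12 log units; within the scatter) not beyond the scatter, estimated at 30000 nM within 7000 nM to 130000 nM.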

Compound 3, half-maximal inhibitory concentration: 6310 nM
Estimate against measurement, compound 3: 4.8-fold (0.68 log units) above, outside the stated range (below it).
By their numbers in this assay, from the lowest: compound 1; then compound 3; then compound 2.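

With the same atoms on the triple-bonded carbon, merely joined differently, the exchange gives a 6.3-fold lower number from compound 2 to compound 3 (0.80 log units; beyond the scatter), so in this assay this position responds to how the group is built and not only to what it contains. Even so, the change still gives a 4.0-fold higher number from compound 1 to compound 3 (0.60 log units; beyond the scatter), leaving compound 1, with its ring of 1 hetero atom, with the lowest number of the three. Nothing given here explains either step.

As far as these compounds go, what remains open is whether a ring carrying an amine or a carboxylic acid in place of its triple bond would fall nearer compound 1 or compound 3.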